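Swapping the aniline ring for an indole on a shared core

This account rests on a few compounds, and the source may have more. Where it says the series, first, only, none or still open, it means among the compounds named here.

Compound 1 `COc1ccc(Nc2ncc3cc(S(=O)(=O)c4ccc(C)cc4)c(=O)n(C)c3n2)cc1` gives 75000 nM in a functional assay on K562 cells (Homo sapiens) for inhibition, read by trypan blue exclusion, with a stated time of 72 h (on this read-out lower numbers stand for stronger inhibition and higher numbers for weaker inhibition), the highest of the three numbers shown. Within the data shown here, compound 2 `COc1ccc(Nc2ncc3cc(S(=O)(=O)c4ccc(Cl)cc4)c(=O)n(C)c3n2)cc1` gives 15000 nM, and the step of a 5.0-fold lower number from compound 1 to compound 2 (0.70 log units; beyond the scatter) is the only single change measured here. Compound 3 `Cn1c(=O)c(S(=O)(=O)c2ccc(F)cc2)cc2cnc(Nc3ccc4[nH]ccc4c3)nc21`, which carries an indole and a fluoro group, gives 200 nM; it differs from compound 1 in two places, so its far lower number cannot be split between them. Compound 4 `Cc1ccc(S(=O)(=O)c2cc3cnc(Nc4cccc5[nH]ccc45)nc3n(C)c2=O)cc1` differs from compound 1 by 1H-indol-4-yl in place of 4-methoxyphenyl on a nitrogen on an aromatic ring. Among the measured compounds shown here, no measured step tests this indole change alone, but the values of compound 1 and compound 3 suggest an indole on that nitrogen goes with a much lower number. For compound 4 a step of a 9.4-fold lower number from compound 1 to compound 4 (0.97 log units; beyond the scatter) is therefore expected, giving an estimated 8000 nM with a range of 1500 nM to 40000 nM.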

Compound 4, half-maximal inhibitory concentration: 5000 nM
The estimate for compound 4 lay 1.6-fold (0.20 log units) above the measured number, and the stated range covers the measured number.
By their numbers in this assay, from the lowest: compound 3; then compound 4; then compound 2; then compound 1.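

Among these compounds, this is the first single change read at this nitrogen: in this assay, 1H-indol-4-yl in place of 4-methoxyphenyl gives a 15-fold lower number from compound 1 to compound 4 (1.18 log units; beyond the scatter). With the rest of compound 1 unchanged, the lower number belongs to this swap alone, and the step is large. Nothing available here bears on why the number falls.

From the compounds shown here alone, it remains open whether a phenyl ring carrying an amine on that nitrogen would give a similarly low number. Also open, going by these compounds, is whether chloro in place of methyl would lower the number again alongside 1H-indol-4-yl.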